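This account rests on a few compounds, and the source may have more. Where it says the series, first, only, none or still open, it means among the compounds named here.

Measured compounds:
compound 1 `O=C(Nc1ccc(-n2ncc3c(C(F)(F)F)cccc32)cc1)Nc1ccc(Cl)c(C(F)(F)F)c1` — 16000 nM
compound 2 `O=C(Nc1ccc(-n2ncc3c(Br)cccc32)cc1)Nc1ccc(Cl)c(C(F)(F)F)c1` — 1300 nM
compound 3 `CNc1cccc2c1cnn2-c1ccc(NC(=O)Nc2ccc(Cl)c(C(F)(F)F)c2)cc1` — 5000 nM

In a functional assay on Bel-7402 cells (Homo sapiens) for cytotoxicity, read by MTT assay, with a stated time of 72 h (on this read-out lower numbers stand for stronger inhibition and higher numbers for weaker inhibition), compound 2 gives the lowest of the three numbers; the step of a 3.8-fold higher number from compound 2 to compound 3 (0.59 log units; beyond the scatter) and the step of a 12-fold lower number from compound 1 to compound 2 (1.09 log units; beyond the scatter) both set it clearly apart, and the step of a 3.2-fold lower number from compound 1 to compound 3 (0.51 log units; beyond the scatter) places compound 3 between the other two. All three measured compounds share the same core and differ only in one group on the fused ring system.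

Compound 4 `O=C(Nc1ccc(-n2ncc3cccnc32)cc1)Nc1ccc(Cl)c(C(F)(F)F)c1` is not yet measured. It differs from compound 2 by a group of 9 heavy atoms (6 carbon, 3 nitrogen; one five-membered aromatic ring with 2 hetero atoms, one six-membered aromatic ring with 1 hetero atom) in place of a group of 10 heavy atoms (7 carbon, 2 nitrogen, 1 bromine; one five-membered aromatic ring with 2 hetero atoms, one six-membered aromatic ring of carbon only), on an aromatic carbon. Going by the values given here, no measured step makes exactly this change, so only an indirect reading is possible: every change away from the bromo group of compound 2 that has been measured, namely a 3.8-fold higher number from compound 2 to compound 3 (0.59 log units; beyond the scatter) and, read backwards, a 12-fold lower number from compound 1 to compound 2 (1.09 log units; beyond the scatter), gave a higher number. Compound 4 also loses the bromo group, and a higher number in this assay is therefore expected, by a step of about a 4.6-fold higher number from compound 2 to compound 4 (0.66 log units; beyond the scatter). For compound 4 the expected value is 6000 nM, with a range from 2000 nM to 20000 nM.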

Compound 4, half-maximal inhibitory concentration: 20900 nM
For compound 4 the middle estimate is 3.5-fold (0.54 log units) below the measured one, outside the stated range (above it).
By their numbers in this assay, from the lowest: compound 2; then compound 3; then compounds 1 and 4 (each within the scatter of the next).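

In this assay, the step of a 16-fold higher number from compound 2 to compound 4 (1.21 log units; beyond the scatter) means that all three measured changes away from the 4-bromo-1H-indazol-1-yl group of compound 2 now give a higher number, with compounds 1, 3 and 4 all going the same way. Unlike compounds 1 and 3, compound 4 alters the ring itself, since a ring of carbon only becomes one with a hetero atom and the bromo group goes, yet its number lies within the usual scatter of that of compound 1. No measurement at hand gives a reason for this step.

The compounds shown cannot separate the loss of the bromo group from the arrival of the ring nitrogen. On these data alone, how a chloro or methoxy group would compare with bromo on this carbon also remains open.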